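Amino-quinoline series: ring substituent and MCF7 growth inhibition

A few compounds are considered here, and "the series" means these few. Any claim that something is new, unique, unknown or untested is made for them only; others in the source may bear on it.

Measured so far:
compound 1 `CN(C)CCNc1ccnc2cc(Cl)ccc12`: 15400 nM
compound 2 `CN(C)CCNc1ccnc2cc(F)ccc12`: 3420 nM

Among the measured compounds shown here, in a functional assay on MCF7 cells (Homo sapiens) for cytotoxicity, read by sulforhodamine B assay, with a stated time of 48 h (a higher number here means a weaker inhibitor of growth, a lower number a stronger inhibitor of growth), compound 2 gives 3420 nM, the lowest of the two numbers in hand; its only neighbour, compound 1, gives 15400 nM. For the measured compounds named here, the one measured step, a 4.5-fold lower number from compound 1 to compound 2 (0.65 log units; beyond the scatter), shows that exchanging the substituent on the carbon-only ring of the shared core moves the number by a modest but real amount.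

Compound 3 `COc1ccc2c(NCCN(C)C)ccnc2c1` is not yet measured. It differs from compound 2 by methoxy in place of fluoro on an aromatic carbon. The step from compound 1 to compound 2 is the only one that touches this position, and it concerned a different exchange, so it sets the scale rather than the direction. A step of similar size in either sense is plausible; no change beyond the scatter is the central expectation, with the wide range reflecting the thin precedent. The step expected is a 1.5-fold higher number from compound 2 to compound 3 (0.16 log units; within the scatter). For compound 3 the estimate in this assay is 5000 nM, within 1500 nM to 16000 nM.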

Compound 3, concentration for 50% growth inhibition: 3890 nM
Compound 3: the middle estimate sits 1.3-fold (0.11 log units) above what was measured; the measured number falls inside the stated range.
By their numbers in this assay, from the lowest: compounds 2 and 3 (each within the scatter of the next); then compound 1.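

In this assay, methoxy in place of fluoro gives a 1.1-fold higher number from compound 2 to compound 3 (0.06 log units; within the scatter), so at this position on the carbon-only ring, a group with one more heavy atom and a hydrogen-bond acceptor leaves the number within the scatter of the fluoro value. Methoxy in place of chloro gives a 4.0-fold lower number from compound 1 to compound 3 (0.60 log units; beyond the scatter), so among the three groups seen here, chloro alone stands apart, with both other groups beyond the scatter of it. The data in hand offer no independent measurement that would account for this separation.

Open, going by these compounds, is whether an amine, a carboxylic acid or a trifluoromethyl group at this position would fall with fluoro and methoxy or with chloro. Also open, on these data alone, is how a longer chain in place of the shared side chain would move the number.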